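The source may hold more compounds than are shown below. What is called first, only, known or untested is meant among the compounds shown, and "the series" means these compounds.

In a functional assay on Ehrlich cells (Mus musculus) for cytotoxicity, read by MTT assay, with a stated time of 24 h (on this read-out lower numbers stand for stronger inhibition and higher numbers for weaker inhibition), compound 3 `C[C@H](Nc1nc2cc(Cl)c(F)cc2s1)c1ccc(F)cc1` gives 35400 nM, the lowest of the three numbers shown, though compound 1 `C[C@H](Nc1nc2cc(Cl)c(F)cc2s1)c1ccccc1` with 36600 nM lies within the scatter of it (a 1.0-fold lower number from compound 1 to compound 3 (0.01 log units; within the scatter)), while compound 2 `COc1ccc([C@H](C)Nc2nc3cc(Cl)c(F)cc3s2)cc1` gives 75400 nM, a modest step away (a 2.1-fold lower number from compound 2 to compound 3 (0.33 log units; beyond the scatter)). Compound 4 `C[C@H](Nc1nc2cc(Cl)c(F)cc2s1)C1CCCCC1` differs from compound 3 by cyclohexyl in place of 4-fluorophenyl on a saturated chain carbon bound to a nitrogen on an aromatic ring and a saturated chain carbon. Going by the values given here, none of the measured steps tests a swap of one whole ring for another; they only vary a single group on the ring that now leaves (a 2.1-fold higher number from compound 1 to compound 2 (0.31 log units; beyond the scatter)). Because a 1.0-fold lower number from compound 1 to compound 3 (0.01 log units; within the scatter) was within the scatter, the fluoro itself changed nothing measurable. The expected step of a 1.1-fold higher number from compound 3 to compound 4 (0.05 log units; within the scatter) in this assay is therefore uncertain, and compound 4 is estimated at 40000 nM, with a range from 14000 nM to 115000 nM.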

Compound 4, half-maximal inhibitory concentration: 29800 nM
Beside the measured number, compound 4's estimate is 1.3-fold (0.13 log units) above it; measured number inside the range.
By their numbers in this assay, from the lowest: compounds 4, 3 and 1 (each within the scatter of the next); then compound 2.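

Going by these compounds alone, this is the first test of a whole ring swap at this position, on a saturated chain carbon bound to a nitrogen on an aromatic ring and a saturated chain carbon: cyclohexyl in place of 4-fluorophenyl stays within the scatter (a 1.2-fold lower number from compound 3 to compound 4 (0.07 log units; within the scatter)), as does cyclohexyl in place of phenyl (a 1.2-fold lower number from compound 1 to compound 4 (0.09 log units; within the scatter)). In this assay, an aromatic ring at this position is therefore not required to retain this level of cytotoxicity among these compounds. No available evidence explains this result. Still open, as far as these compounds go, is whether an amine or carboxylic acid on the ring, or a longer chain replacing the ring, would shift the number beyond the scatter.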